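A few compounds are considered here, and "the series" means these few. Any claim that something is new, unique, unknown or untested is made for them only; others in the source may bear on it.

Compounds measured in an ADME assay on Vero 76 cells (Chlorocebus sabaeus) for cytotoxicity, read by crystal violet staining, with a stated time of 96 h; a lower number here means that less compound is tolerated, a higher number that more compound is tolerated:
compound 1 `COc1cccc(NC(=S)Nc2cccc(C(F)(F)F)c2)c1`: 20000 nM
compound 2 `Cc1ccc(NC(=S)Nc2cccc(C(F)(F)F)c2)cc1Cl`: 20000 nM

Compound 1 stands level with compound 2 at the digits shown, the two values lying within the scatter of each other. Compound 3 `Fc1cccc(NC(=S)Nc2cccc(C(F)(F)F)c2)c1` has not yet been measured. It differs from compound 1 by fluoro in place of methoxy on an aromatic carbon. Among the compounds with values here, since no step between measured compounds is available, there is nothing to point to a change in either direction, and no step beyond the scatter is expected. For compound 3 the expected value in this assay is 20000 nM, with a range from 10000 nM to 40000 nM, meaning an expected step of no change at the digits printed from compound 1 to compound 3 (within the scatter).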

Compound 3, half-maximal cytotoxic concentration: 20000 nM
Estimate against measurement, compound 3: no gap at the digits printed; the measured number falls inside the stated range.
By their numbers in this assay, from the lowest: compounds 1, 2 and 3 (each within the scatter of the next).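

In this assay the step is no change at the digits printed from compound 1 to compound 3 (within the scatter) for fluoro in place of methoxy on an aromatic carbon, meta to a large group. Within the data shown here, this is the first comparison at this position, since compounds 1 and 2 differ in more than one place. It shows that this exchange of one group for another leaves the tolerated concentration unchanged within the scatter. No evidence is available that would explain this result. Still open, going by these compounds, is whether an amine, a carboxylic acid or a longer chain at this position would also leave the value in place.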